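Permeability notes on the tetrazolyl benzylamide series

The source may hold more compounds than are shown below. What is called first, only, known or untested is meant among the compounds shown, and "the series" means these compounds.

Measured so far:
- compound 1, `O=C(NCc1cc(Cl)ccc1-n1cnnn1)[C@@H]1C[C@@H]2C[C@@H]2N1C(=O)[C@H](O)Cc1ccccn1`: 1.2 10^-6 cm/s
- compound 2, `O=C(NCc1cc(Cl)ccc1-n1cnnn1)[C@@H]1[C@H]2C[C@H]2CN1C(=O)[C@H](O)c1ccccc1`: 12 10^-6 cm/s

In an ADME assay on Caco-2 cells (Homo sapiens) for permeability, read by LC-MS, in the apical to basolateral direction, with a stated time of 60 min, at pH 6.5 (on this read-out lower numbers stand for lower permeability and higher numbers for higher permeability), compound 1 gives 1.2 10^-6 cm/s, the lower of the two numbers; compound 2 sits higher, and the gap lies beyond the scatter. Among the measured compounds shown here, no structural step between the two measured compounds can be read off.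

Compound 3, `O=C(NCc1cc(Cl)ccc1-n1cnnn1)[C@@H]1C[C@@H]2C[C@@H]2N1C(=O)[C@H](O)Cn1cccn1`, differs from compound 1 by 1H-pyrazol-1-yl in place of pyridin-2-yl on a saturated chain carbon, two bonds along the chain from a carbonyl carbon and an oxygen on a saturated carbon. The reading of compound 2 is not informative for this change. For compound 3 the step of a 1.2-fold lower number from compound 1 to compound 3 (0.08 log units; within the scatter) is expected to be small, within the scatter, with no clear direction. Compound 3 is therefore estimated at 1 10^-6 cm/s, within 0.4 10^-6 cm/s to 2.5 10^-6 cm/s.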

Compound 3, apparent permeability: 0.45 10^-6 cm/s
Compound 3: middle estimate off by 2.2-fold (0.35 log units), on the high side; low and high end bracket the measured number.
By their numbers in this assay, from the lowest: compound 3; then compound 1; then compound 2.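

At this position, on a saturated chain carbon two bonds along the chain from a carbonyl carbon and an oxygen on a saturated carbon, exchanging pyridin-2-yl for 1H-pyrazol-1-yl gives in this assay a 2.7-fold lower number from compound 1 to compound 3 (0.43 log units; beyond the scatter) as a modest step. Among the compounds shown here, it is the first single-place step, so the number at this position does respond to the aromatic ring it carries. Nothing at hand accounts for the step.

Open, on these data alone, is whether an amine or a carboxylic acid in place of the ring would move the number further, or in which direction. Also open, as far as these compounds go, is whether the same exchange gives a similar step on the core of compound 2.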